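Changing the Amine at the End of the Chain

A few compounds are considered here, and "the series" means these few. Any claim that something is new, unique, unknown or untested is made for them only; others in the source may bear on it.

Measured so far:
compound 1 `CN(C)CCCCCCOc1ccc2oc(-c3ccccc3)cc(=O)c2c1` gives 335 nM;
compound 2 `CN(C)CCCCCCCOc1ccc2oc(-c3ccccc3)cc(=O)c2c1` gives 188 nM;
compound 3 `O=c1cc(-c2ccccc2)oc2ccc(OCCCCCCN3CCCC(O)C3)cc12` gives 77 nM.

In an assay on isolated protein (Cavia porcellus) with Sigma non-opioid intracellular receptor 1 (Homo sapiens) as the target, read by radioligand binding (on this read-out higher numbers stand for weaker inhibition and lower numbers for stronger inhibition), compound 3 stands with the lowest number of the three, beyond the scatter from both others. All three share the same core and the same ether-linked chain; they differ only in the amine at its end. Going a 1.8-fold lower number from compound 1 to compound 2 (0.25 log units; within the scatter) stays within the scatter, whereas the change to the cyclic amine, a 4.4-fold lower number from compound 1 to compound 3 (0.64 log units; beyond the scatter) and a 2.4-fold lower number from compound 2 to compound 3 (0.39 log units; beyond the scatter), gave modest improvements.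

Compound 4 `O=c1cc(-c2ccccc2)oc2ccc(OCCCCCCN3CCNCC3c3ncccn3)cc12` is not yet measured. It differs from compound 3 by 2-(pyrimidin-2-yl)piperazin-1-yl in place of 3-hydroxypiperidin-1-yl on a saturated chain carbon, six bonds along the chain from an oxygen on an aromatic ring. The entering group is again a cyclic amine on a saturated chain carbon, six bonds along the chain from an oxygen on an aromatic ring, but it is larger and carries an aromatic ring of its own. The measured steps show only that a cyclic amine in this place was tolerated and helped modestly; none tells what a second ring does. The expectation for compound 4 is therefore a step of about a 1.1-fold lower number from compound 3 to compound 4 (0.04 log units; within the scatter), that is, no change beyond the scatter. Compound 4 is estimated at 70 nM, within a range from 15 nM to 300 nM.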

Compound 4, half-maximal inhibitory concentration: 14200 nM
For compound 4 the middle estimate is 200-fold (2.31 log units) below the measured one; the whole stated range lies below it.
By their numbers in this assay, from the lowest: compound 3; then compounds 2 and 1 (each within the scatter of the next); then compound 4.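

In this assay the swap of 3-hydroxypiperidin-1-yl for 2-(pyrimidin-2-yl)piperazin-1-yl gives a 180-fold higher number from compound 3 to compound 4 (2.27 log units; beyond the scatter) and so shows that being a cyclic amine is not enough to keep the number low at this place on the chain. The earlier compounds shown here gave no sign of such a sharp limit, yet the entering group also gives a 76-fold higher number from compound 2 to compound 4 (1.88 log units; beyond the scatter) and a 42-fold higher number from compound 1 to compound 4 (1.63 log units; beyond the scatter) when set against the two smaller open-chain amines, so compound 4 stands beyond the scatter from all three earlier compounds on the weak side. No measurement available here accounts for this large rise.

The entering group brings a second ring and further nitrogen atoms all at once, so the compounds shown cannot tell which of these changes goes with the rise. Plain piperazin-1-yl on the same chain would help to separate them, and a phenyl group in place of the pyrimidin-2-yl ring would show whether the ring nitrogens of that aromatic ring matter.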